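The compounds below may be only part of what the source reports. "The series", "measured", "known", "first", "only" and "open" are said of these compounds alone.

Compound 3 `CC(C)c1c(CC2CCCCC2)nc(SCc2ccccc2)[nH]c1=O` stands second highest of the three numbers in an ADME assay on C1866 cells (Homo sapiens) for cytotoxicity, read by MTT assay, with a stated time of 72 h (on this read-out higher numbers stand for an effect only at larger amounts of compound and lower numbers for an effect already at smaller amounts), where compound 3 gives 0.088 nM. Its nearest neighbour is compound 1 `CC(C)c1c(CC2CCCCC2)nc(SCC(=O)c2ccccc2)[nH]c1=O`, which gives 0.025 nM; the step of a 3.5-fold higher number from compound 1 to compound 3 (0.55 log units; beyond the scatter) is modest. Compound 2 `CC(C)CSc1nc(CC2CCCCC2)c(C(C)C)c(=O)[nH]1` lies furthest away, with 92.9 nM, and the step of a 1100-fold lower number from compound 2 to compound 3 (3.02 log units; beyond the scatter) is large, as is the step of a 3700-fold higher number from compound 1 to compound 2 (3.57 log units; beyond the scatter). Compound 4 `CCc1c(CC2CCCCC2)nc(SCc2ccccc2)[nH]c1=O` differs from compound 3 by hydrogen in place of methyl on a saturated chain carbon bound to an aromatic carbon and a saturated chain carbon. All three measured steps alter the group on the saturated chain carbon bound to a sulfur, so none of them bears on this change, and the data are silent on it. The step of a 1.1-fold higher number from compound 3 to compound 4 (0.06 log units; within the scatter) is therefore expected to stay within the scatter. Compound 4 is estimated at 0.1 nM, within 0.02 nM to 0.5 nM.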

Compound 4, half-maximal effective concentration: 532 nM
The estimate for compound 4 lay 5300-fold (3.73 log units) below the measured number; measured number above the stated range.
By their numbers in this assay, from the lowest: compound 1; then compound 3; then compound 2; then compound 4.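

In this assay, for the compounds shown here, the isopropyl to ethyl change gives a 6000-fold higher number from compound 3 to compound 4 (3.78 log units; beyond the scatter), so the place on the saturated chain carbon bound to an aromatic carbon and a saturated chain carbon, untouched by the earlier steps, proves highly sensitive. The loss of a single methyl here is enough for a large step, of the same class as the largest steps at the sulfur-bound chain carbon. No evidence is given that accounts for this step. From the compounds shown here alone, whether a longer chain or an amine at this place would restore the small number of compound 3 remains open, as does whether the step keeps its size with the other groups on the sulfur-bound chain carbon.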